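Extending a para-alkyl chain on a cinnamamide

The source may hold more compounds than are shown below. What is called first, only, known or untested is meant among the compounds shown, and "the series" means these compounds.

Measured so far:
compound 1, `CCCc1cc(N)c2cc(NC(=O)/C=C/c3ccc(CC)cc3)ccc2n1`: 1.4 nM
compound 2, `CCCc1cc(N2CCCC2)c2cc(NC(=O)/C=C/c3ccc(C(F)(F)F)cc3)ccc2n1`: 17 nM
compound 3, `CCCc1cc(N)c2cc(NC(=O)c3ccc(C(F)(F)F)cc3)ccc2n1`: 10000 nM

All three compounds were tested in an assay on isolated protein for displacement of a labelled ligand from melanin-concentrating hormone receptor 1 (Homo sapiens); a lower number here means a stronger inhibitor, a higher number a weaker inhibitor. Compound 1 gives the lowest number of the three. Compound 2 sits a good deal higher, beyond the scatter of this assay, and compound 3 lies far higher still, also well beyond the scatter. No pair among these three differs in only one place, so no single step can be read off from them; the values only show that compound 1 is the strongest inhibitor of the group.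

Compound 4, `CCCCc1ccc(/C=C/C(=O)Nc2ccc3nc(CCC)cc(N)c3c2)cc1`, has not yet been measured. It differs from compound 1 in one place: ethyl in place of hydrogen on a saturated chain carbon, two bonds along the chain from an aromatic carbon. In other words, ethyl in place of hydrogen on a saturated chain carbon, two bonds along the chain from an aromatic carbon, so the ethyl of compound 1 becomes a butyl. For the measured compounds named here, nothing among the measured compounds probes a change of this kind, so the expectation rests on compound 1 alone and on the small size of the change. The step is expected to be modest, if anything toward a slightly higher number, as a 2.1-fold higher number from compound 1 to compound 4 (0.33 log units; beyond the scatter). Compound 4 is thus estimated at 3 nM, within a range from 0.8 nM to 12 nM.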

Compound 4, half-maximal inhibitory concentration: 45 nM
Beside the measured number, compound 4's estimate is 15-fold (1.18 log units) below it; the whole stated range lies below it.
By their numbers in this assay, from the lowest: compound 1; then compound 2; then compound 4; then compound 3.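

In this assay, lengthening the chain from ethyl to butyl turns out to be a large change, not a minor adjustment: the step is a 32-fold higher number from compound 1 to compound 4 (1.51 log units; beyond the scatter), well beyond the scatter. For the compounds shown here, this is the first direct view of this position, since no earlier pair differed in only one place, and it shows that adding an ethyl to this saturated chain carbon, two bonds along the chain from an aromatic carbon, can greatly weaken inhibition on the core of compound 1. Nothing available explains why the longer chain has this effect.

A single step cannot show whether the number climbs gradually or sharply as the chain grows, and a propyl chain would help to settle that. Going by these compounds, it also remains open how a branched isopropyl group or a chain ending in an amine would fare here.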